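The compounds below may be only part of what the source reports. "The series", "measured", "known", "first", "only" and "open" are said of these compounds alone.

Measured so far:
- compound 1 `CCCC(Oc1ccc(-n2cc(F)cn2)cc1)c1ccc(C(=O)NCCC(=O)O)cc1`: 10000 nM
- compound 2 `CCCC(Nc1cc(C)c(-n2cc(C(F)(F)F)cn2)c(C)c1)c1ccc(C(=O)NCCC(=O)O)cc1`: 1400 nM
- compound 3 `CCCC(Oc1ccc(-n2cc(C(F)(F)F)cn2)nc1)c1ccc(C(=O)NCCC(=O)O)cc1`: 3700 nM

In a functional assay on cells for antagonist activity at Glucagon receptor (Homo sapiens), read by cAMP accumulation, in the presence of a further agent that is not named here (on this read-out higher numbers stand for weaker inhibition and lower numbers for stronger inhibition), compound 1 gives 10000 nM, the highest of the three numbers, which on this read-out makes it the weakest inhibitor of the set. Compound 3 stands nearest to it, compound 2 furthest, and both lie beyond the scatter of repeated measurements. Among the measured compounds shown here, both compound 2 and compound 3 carry a trifluoromethyl on the pyrazole, while compound 1 carries only a fluorine there; the other parts of these three structures also differ, so no single step between measured compounds is available.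

Compound 4 `CCCC(Oc1ccc(-n2cc(C(F)(F)F)c(C)n2)cc1)c1ccc(C(=O)NCCC(=O)O)cc1` is the next analogue of this series. Its structure differs from compound 1 in one place: 3-methyl-4-(trifluoromethyl)-1H-pyrazol-1-yl in place of 4-fluoro-1H-pyrazol-1-yl on an aromatic carbon.

For the measured compounds named here, with no measured step of this kind, the expectation rests on the comparison of compound 1 with compound 2 and compound 3. In this assay a step from compound 1 to compound 4 of a 6.7-fold lower number from compound 1 to compound 4 (0.82 log units; beyond the scatter) is expected, toward a lower number and beyond the scatter. Compound 4 is therefore estimated at 1500 nM, with a range from 500 nM to 5000 nM.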

Compound 4, antagonist equilibrium constant: 8300 nM
For compound 4 the middle estimate is 5.5-fold (0.74 log units) below the measured one, outside the stated range (above it).
By their numbers in this assay, from the lowest: compound 2; then compound 3; then compounds 4 and 1 (each within the scatter of the next).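

In this assay, among the compounds shown here, exchanging 4-fluoro-1H-pyrazol-1-yl for 3-methyl-4-(trifluoromethyl)-1H-pyrazol-1-yl on an aromatic carbon, para to a large group, gives a 1.2-fold lower number from compound 1 to compound 4 (0.08 log units; within the scatter) as the first step that can be read at a single place. On the core of compound 1, the two substituted pyrazoles therefore cannot be told apart at this position, even though the entering group carries both a trifluoromethyl and a methyl. No measurement available here accounts for this outcome.

The step changes the pyrazole substitution in more than one way at once, so the separate contributions of the methyl, the trifluoromethyl and the loss of the fluorine remain unresolved, as does whether 4-(trifluoromethyl)-1H-pyrazol-1-yl without the methyl would behave like either compound on this core. Also open, as far as these compounds go, is whether a pyrazole bearing a nitrile, a methoxy group or an amine at this position would give a number beyond the scatter from compound 1 and compound 4.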